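A Sulfamoyl Benzyl Analogue Expected to Remain Non-Toxic

The compounds below may be only part of what the source reports. "The series", "measured", "known", "first", "only" and "open" are said of these compounds alone.

Of the compounds shown here, three sharing one core have been tested in an ADME assay on MT4 cells (Homo sapiens) for cytotoxicity, read by MTT assay, with a stated time of 4 days; on this read-out lower numbers stand for higher toxicity in this test and higher numbers for lower toxicity in this test. Compound 1 `CCOC(=O)c1cnc(N2CCN(Cc3cccc(C(F)(F)F)c3)CC2)nc1Oc1c(C)cc(-c2ccc(C#N)cc2)cc1C` carries a 3-(trifluoromethyl)phenyl group on a saturated chain carbon bound to an amine nitrogen in a ring. In this assay compound 1 gives > 125000 nM, a limit of the test rather than a number. Compound 2 `CCOC(=O)c1cnc(N2CCN(Cc3ccc(C(=O)OC)cc3)CC2)nc1Oc1c(C)cc(-c2ccc(C#N)cc2)cc1C` has 4-(methoxycarbonyl)phenyl at the same place. In this assay compound 2 also reaches > 125000 nM, again a limit. Compound 3 `CCOC(=O)c1cnc(N2CCN(Cc3ccccc3[N+](=O)[O-])CC2)nc1Oc1c(C)cc(-c2ccc(C#N)cc2)cc1C` bears 2-nitrophenyl there. Compound 3 gives >= 78700 nM in this assay, likewise a limit. Every comparison among them is therefore unreadable: a step that the two limits leave unreadable from compound 1 to compound 2, a step that the two limits leave unreadable from compound 1 to compound 3, a step that the two limits leave unreadable from compound 2 to compound 3. Compound 2 thus stands at the limit of > 125000 nM in this assay, at which 2 of the 3 values shown sit, while the limit of >= 78700 nM in this assay, at which 1 of the 3 values shown sits, is the other limit recorded.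

Compound 4 `CCOC(=O)c1cnc(N2CCN(Cc3ccc(S(N)(=O)=O)cc3)CC2)nc1Oc1c(C)cc(-c2ccc(C#N)cc2)cc1C` differs from compound 2 by sulfamoyl in place of methoxycarbonyl on an aromatic carbon. Among the measured compounds shown here, no measured step bears readably on this change, and none of the three aryl groups tried at this position brought any compound into the measurable range. Compound 4 is therefore expected to show no step beyond the scatter, a number no higher from compound 2 to compound 4 (the limit leaves the size open). Compound 4 is estimated in this assay at 125000 nM, with a range from 50000 nM to 250000 nM, most likely reported only as a limit.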

Compound 4, half-maximal cytotoxic concentration: >= 7930 nM
Compound 4: a limit, no number; the forecaster's own chance of this, stated with the estimate: 85%; the middle value lies beyond the limit too.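

In this assay compound 4 gives >= 7930 nM, a limit of the test and not a number. With only limits on both sides, the steps from compound 1, compound 2 and compound 3 to compound 4 cannot be read. The compounds shown leave open where any of the four would reach a measurable value in this assay, and whether sulfamoyl in place of methoxycarbonyl shifts that value at all.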